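From chloro to fluoro: a small step expected

A few compounds are considered here, and "the series" means these few. Any claim that something is new, unique, unknown or untested is made for them only; others in the source may bear on it.

In an ADME assay on THP-1 cells (Homo sapiens) for cytotoxicity, read by flow cytometry and propidium iodide staining, with a stated time of 72 h (a lower number here means a stronger inhibitor, a higher number a weaker inhibitor), compound 3 (`Cc1nc(CS(=O)(=O)c2ccc(Cl)cc2)c([N+](=O)[O-])n1CCO`) gives 578000 nM, the higher of the two true numbers in this small set. Compound 2 (`Cc1ccc(S(=O)(=O)Cc2nc(C)n(CCO)c2[N+](=O)[O-])cc1`) gives 59000 nM, and the modest step between them is a 9.8-fold higher number from compound 2 to compound 3 (0.99 log units; beyond the scatter). Compound 1 (`Cc1nc(CS(=O)(=O)c2ccccc2)c([N+](=O)[O-])n1CCO`) returns only a limit of the assay, > 768000 nM.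

Compound 4 (`Cc1nc(CS(=O)(=O)c2ccc(F)cc2)c([N+](=O)[O-])n1CCO`) differs from compound 3 at a single place, with fluoro in place of chloro on an aromatic carbon. Among the compounds with values here, no measured step makes this exact exchange, so the nearest evidence is indirect. Chloro in place of hydrogen gave an at least 1.3-fold lower number from compound 1 to compound 3 (0.12 log units; that floor lies within the scatter), whose floor does not clear the scatter. Methyl in place of hydrogen gave a large step, an at least 13-fold lower number from compound 1 to compound 2 (1.11 log units; beyond the scatter), so a change at this place is not always silent, and the range has to stay wide. As compound 3 and compound 1 lie close to each other on the numbers available, the exchange is expected to produce no step beyond the scatter. The expected step is a 1.0-fold higher number from compound 3 to compound 4 (0.02 log units; within the scatter). Compound 4 could also return only a limit. For compound 4 the estimated value is 600000 nM, with an expected range of 250000 nM to 1200000 nM.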

Compound 4, half-maximal inhibitory concentration: > 728000 nM
Compound 4: only a limit was reported; the forecaster's own chance of this, stated with the estimate: 35%; middle value at least 1.2-fold (0.08 log units) from the limit.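

In this assay compound 4 is reported only as a limit of the assay: the limit of > 728000 nM in this assay, at which 1 of the 4 values shown sits. Within the data shown here, at this place, para to a large group, fluoro in place of chloro gives an at least 1.2-fold higher number from compound 3 to compound 4 (0.10 log units; that floor lies within the scatter), so the fluoro exchange opens no step that can be told from the scatter, and the data do not separate these two halogens. Fluoro in place of methyl gives an at least 12-fold higher number from compound 2 to compound 4 (1.09 log units; beyond the scatter), which matches the earlier 9.8-fold higher number from compound 2 to compound 3 (0.99 log units; beyond the scatter) in direction, and so among the four compounds shown only the methyl compound carries a number clearly lower than the rest, with no compound here going against that.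

The step between compound 1 and compound 4 cannot be read, and neither compound has a true number in this set. The compounds shown leave open whether the low number of compound 2 belongs to methyl alone or would also appear with a longer chain such as ethyl, or with an amine or a methoxy group at this place.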